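Working notes on furan variation, compounds 1 to 4

The compounds below may be only part of what the source reports. "The series", "measured", "known", "first", "only" and "open" are said of these compounds alone.

Measured compounds:
compound 1 `COc1ccc(OC)c(C(=O)/C=C/c2ccco2)c1`: 10500 nM
compound 2 `COc1ccc(OC)c(C(=O)/C=C/c2ccoc2)c1`: 18200 nM
compound 3 `COc1ccc(OC)c(C(=O)/C=C/c2ccc(C)o2)c1`: 10300 nM

In a functional assay on MCF7 cells (Homo sapiens) for cytotoxicity, read by MTT assay (on this read-out lower numbers stand for stronger inhibition and higher numbers for weaker inhibition), compound 1 gives 10500 nM, compound 2 gives 18200 nM and compound 3 gives 10300 nM. Compound 3 carries the lowest of the three numbers, yet the steps of a 1.0-fold lower number from compound 1 to compound 3 (0.01 log units; within the scatter) and a 1.8-fold lower number from compound 2 to compound 3 (0.25 log units; within the scatter) both lie within the scatter, so no order among the three compounds is claimed.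

Compound 4 `COc1ccc(OC)c(C(=O)/C=C/c2occc2Br)c1` is not yet measured. Against compound 3 the change is 3-bromofuran-2-yl in place of 5-methylfuran-2-yl on a double-bonded chain carbon bound to a double-bonded chain carbon. The measured steps that touch the furan ring are a 1.7-fold higher number from compound 1 to compound 2 (0.24 log units; within the scatter) and a 1.0-fold lower number from compound 1 to compound 3 (0.01 log units; within the scatter); both stay within the scatter, and none of them introduces a bromine, so the data give no direct guide to this substituent. With every change on the furan ring so far leaving the number in place, the step of a 1.1-fold higher number from compound 3 to compound 4 (0.03 log units; within the scatter) is expected to be none beyond the scatter. Compound 4 is therefore estimated at 11000 nM, with a range from 5000 nM to 25000 nM.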

Compound 4, half-maximal inhibitory concentration: 11000 nM
Compound 4: middle estimate and measured number agree at the digits printed, and the stated range covers the measured number.
By their numbers in this assay, from the lowest: compounds 3, 1, 4 and 2 (each within the scatter of the next).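

In this assay, the first halogen on the furan ring leaves the number in place: adding a bromo group to the ring stays within the scatter (a 1.0-fold higher number from compound 1 to compound 4 (0.02 log units; within the scatter)), and so does 3-bromofuran-2-yl in place of 5-methylfuran-2-yl (a 1.1-fold higher number from compound 3 to compound 4 (0.03 log units; within the scatter)). 3-Bromofuran-2-yl in place of furan-3-yl also stays within the scatter (a 1.7-fold lower number from compound 2 to compound 4 (0.22 log units; within the scatter)), so this place on the chain has now tolerated a heavier halogen substituent as well as methyl without a readable change in the number. Nothing available explains this flat response.

The furan rings shown carry only hydrogen, methyl or bromo, which leaves open whether an amine or a carboxylic acid on the ring would move the number beyond the scatter. As far as these compounds go, whether a phenyl ring in place of the furan would do so also remains open.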